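A few compounds are considered here, and "the series" means these few. Any claim that something is new, unique, unknown or untested is made for them only; others in the source may bear on it.

Working notes on the series. The shared core carries a piperazine-like ring whose amine nitrogen bears a varied group. Compound 1 `Nc1scc(CN2CCN(c3ccc([N+](=O)[O-])cc3)CC2)c1C(=O)c1ccc(Cl)cc1` gives in an assay on CHO cells for displacement of a labelled ligand from adenosine receptor A1 (Homo sapiens), read by scintillation counting, with a stated time of 120 min, tested at 10 uM (a higher number here means more inhibition at the concentration tested (going by the name of the read-out), a lower number less inhibition), a value of 1%. Among the compounds with values here, of the three numbers measured so far this is the one that sits highest, yet the steps to the other two fall within the scatter: compound 2 `Nc1scc(CN2CCN(c3ccc(F)c(F)c3)CC2)c1C(=O)c1ccc(Cl)cc1` gives 0% in this assay, and compound 3 `Nc1scc(CN2CCN(c3cc(F)cc(F)c3)CC2)c1C(=O)c1ccc(Cl)cc1` gives 0%. The step of a number 1 percentage points lower from compound 1 to compound 2 (within the scatter) and the step of a number 1 percentage points lower from compound 1 to compound 3 (within the scatter) are both within the scatter, as is the step of no change at the digits printed from compound 2 to compound 3 (within the scatter). Exchanging one aryl group on the ring nitrogen for another thus leaves the read-out at the floor.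

Compound 4 `Nc1scc(CN2CCN(CCCc3ccc(Cl)cc3)CC2)c1C(=O)c1ccc(Cl)cc1` takes a different kind of group at that position:

3-(4-chlorophenyl)propyl in place of 4-nitrophenyl on an amine nitrogen in a ring

Within the data shown here, no measured step exchanges an aryl group on the ring nitrogen for an alkyl chain, so the bearing of the three measured steps is indirect; they show only that changes at this position have not moved the read-out beyond the scatter. On that footing the expected step is a number 2 percentage points higher from compound 1 to compound 4 (within the scatter), that is, none beyond the scatter. Compound 4 is accordingly estimated at 3%, with a range from 0% to 15%.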

Compound 4, a percentage reported as inhibition, at one concentration (the size of the read-out at that concentration, not a potency): 0%
Compound 4: the middle estimate sits 3 percentage points above what was measured, within the range that was stated.
By their numbers in this assay, from the lowest: compounds 2, 3, 4 and 1 (each within the scatter of the next).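

In this assay the 3-(4-chlorophenyl)propyl group on the amine nitrogen in the ring gives a number 1 percentage points lower from compound 1 to compound 4 (within the scatter) and no change at the digits printed from compound 3 to compound 4 (within the scatter) and no change at the digits printed from compound 2 to compound 4 (within the scatter) without leaving the floor of the read-out. Within the data shown here, the earlier compounds exchanged only one aryl group for another on this nitrogen, whereas compound 4 shows that the read-out also stays at the floor when a propyl chain bearing a chlorophenyl ring takes the place of a directly attached aryl group, and when a group with 2 hydrogen-bond acceptors gives way to one with none. Nothing available here accounts for this lack of response at the position.

As far as these compounds go, with all four compounds at the floor, the data give no handle on which features of this substituent could matter, and whether a carboxylic acid, a primary amine at the end of the chain or a chain longer than propyl on this nitrogen would lift the read-out remains open. Equally open, from the compounds shown here alone, is whether a change elsewhere on the shared core, rather than on this nitrogen, would move the read-out at all.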